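The source may report more compounds than this note shows. Statements on the series, on what has been measured and on what is new or still open speak of the compounds shown alone.

Compound 1 `COc1ccc(CN(C(=O)Nc2ccc(Cl)cc2)n2cnnc2)cc1OC` and compound 2 `COc1ccc(CN(C(=O)Nc2ccc(F)c(Cl)c2)n2cnnc2)cc1OC` share one core and differ only in the ring carried on the amide-type nitrogen. In a functional assay on MDA-MB-231 cells (Homo sapiens) for cytotoxicity, read by MTT assay, with a stated time of 48 h (on this read-out higher numbers stand for weaker inhibition and lower numbers for stronger inhibition), compound 1 gives > 50000 nM, which is a limit of the assay rather than a number. In this assay compound 2 gives 27900 nM. Within the data shown here, the single measured step, an at least 1.7-fold lower number from compound 1 to compound 2 (0.25 log units; that floor lies within the scatter), starts from the limit of > 50000 nM in this assay, at which 1 of the 2 values shown sits, and so its true size is not known. Among the measured compounds shown here, compound 2 therefore stands as the only compound with an actual number in this assay. Compound 3 `COc1ccc(CN(C(=O)Nc2ccc(C#N)cc2)n2cnnc2)cc1OC` has not yet been measured; it differs from compound 2 in that (4-cyanophenyl in place of 3-chloro-4-fluorophenyl on an amide-type nitrogen). For the measured compounds named here, no measured step touches a cyanophenyl ring, so the one known step gives little guidance for this change. The step of a 1.3-fold higher number from compound 2 to compound 3 (0.10 log units; within the scatter) is expected to stay within the scatter. Compound 3 is estimated at 35000 nM, with a range from 12000 nM to 100000 nM.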

Compound 3, half-maximal inhibitory concentration: > 50000 nM
Compound 3: only a limit was reported; the forecaster's own chance of this, stated with the estimate: 40%; middle value at least 1.4-fold (0.15 log units) from the limit.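

In this series, 4-cyanophenyl on the amide-type nitrogen joins 4-chlorophenyl in giving only a limit in this assay, so 3-chloro-4-fluorophenyl remains the only ring here with an actual number. Placing 4-cyanophenyl where 3-chloro-4-fluorophenyl stood gives an at least 1.7-fold higher number from compound 2 to compound 3 (0.25 log units; that floor lies within the scatter), and the true size of this step remains unknown. The step between compound 1 and compound 3 cannot be read, because both values are limits: the limit of > 50000 nM in this assay, at which 2 of the 3 values shown sit.

The compounds shown leave open whether the chloro group, the fluoro group or the two together on the ring of compound 2 account for its value of 27900 nM. They also leave open how a ring carrying an amine or a carboxylic acid at this place would read in this assay.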